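The compounds below may be only part of what the source reports. "The series", "measured", "known", "first", "only" and "open" are said of these compounds alone.

Compound 2 `CNC(=O)N1CCCc2ccc(NC(=O)c3ccc(-c4cnn(C)c4)cc3)cc21` belongs to a set of three closely related amides examined in a functional assay on MV4-11 cells (Homo sapiens) for antiproliferative activity, with a stated time of 6 days, tested at 6.25 uM (a higher number here means a stronger effect of the compound at the concentration tested, a lower number a weaker effect), in which compound 2 gives 94.4%. That figure is the second highest of the three numbers shown: compound 1 `CNC(=O)N1CCCc2ccc(NC(=O)c3ccc(-c4ccn(C)n4)cc3)cc21` gives 97%, and compound 3 `CNC(=O)N1CCCc2ccc(NC(=O)c3cccc(-c4cn[nH]c4)c3)cc21` gives 77.7%. Among the measured compounds shown here, the only single-point step among the measured compounds is a number 2.6 percentage points lower from compound 1 to compound 2 (within the scatter), so swapping the point at which the methylated five-membered ring is attached leaves the read-out essentially where it was.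

Compound 4 `CNC(=O)N1CCCc2ccc(NC(=O)c3ccc(-c4ccncc4)cc3)cc21` has not yet been measured. It differs from compound 2 in one place: pyridin-4-yl in place of 1-methyl-1H-pyrazol-4-yl on an aromatic carbon. For the measured compounds named here, no measured step exchanges a five-membered ring for a six-membered one, so the step from compound 1 to compound 2 is the only guide, and it shows that rearranging the ring at this site moved this assay very little. Compound 3 carries its ring at a different site and without a methyl, so its lower number cannot be tied to any single change.

On that basis compound 4 is expected to give a value close to that of compound 2, with a step of a number 4.4 percentage points lower from compound 2 to compound 4 (within the scatter), and its estimate in this assay is 90%, within an expected range from 72% to 99%.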

Compound 4, a percentage reported as inhibition, at one concentration (the size of the read-out at that concentration, not a potency): 88.7%
For compound 4 the middle estimate is 1.3 percentage points above the measured one; low and high end bracket the measured number.
By their numbers in this assay, from the lowest: compound 3; then compounds 4, 2 and 1 (each within the scatter of the next).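

In this assay, replacing a five-membered aromatic ring with a six-membered one on this aromatic carbon, para to a large group, gives a number 5.7 percentage points lower from compound 2 to compound 4 (within the scatter), and the same kind of exchange from the other methylated ring gives a number 8.3 percentage points lower from compound 1 to compound 4 (within the scatter). The earlier step had only moved the attachment point of one methylated five-membered ring, whereas pyridin-4-yl differs from both pyrazole groups in ring size, in having one hetero atom rather than two and in carrying no methyl, and neither step leaves the scatter, so this position accepts all three of these aromatic rings in this read-out. Nothing available explains why the read-out holds across these rings.

From the compounds shown here alone, whether the position would respond in the same way to a non-aromatic group, such as a morpholine ring, a primary amine or a carboxylic acid, remains open. Because the read-out comes from a single concentration, the compounds shown also leave open whether potency differs among compound 1, compound 2 and compound 4.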